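A few compounds are considered here, and "the series" means these few. Any claim that something is new, unique, unknown or untested is made for them only; others in the source may bear on it.

Working notes on the series. In a functional assay on a cell-free system (plasma, Oryctolagus cuniculus) for inhibition, with stated times of 5 min, 1 min and 6 min (on this read-out lower numbers stand for stronger inhibition and higher numbers for weaker inhibition), compound 1 (`CCOC(=O)c1c(C)nc(-c2ccc(OCC(C)C)c(C#N)c2)n1O`) gives 16800 nM while compound 2 (`CCOC(=O)c1c(C)nc(-c2cccc(C#N)c2)n1OC`) gives 9130 nM and compound 3 (`CCOC(=O)c1c(C)nc(-c2ccc(C#N)cc2)n1OC`) gives 13400 nM on the same read-out. Compound 2 lies within the scatter of both other compounds, so the numbers shown do not rank these three. Compound 4 (`CCOC(=O)c1c(C)nc(-c2cccc(C#N)c2)n1OC(C)C`) is still unmeasured and differs from compound 2 in one place. The change is isopropyl in place of methyl on an oxygen on an aromatic ring with isopropyl in place of methyl on an oxygen on an aromatic ring. Among the compounds with values here, no two measured compounds differ in only one place, so the series offers no direct precedent for this change. In this assay the expected 1.1-fold higher number from compound 2 to compound 4 (0.04 log units; within the scatter) stays within the scatter, with no direction favoured. This expectation rests on compound 2 at 9130 nM and on the close agreement of the three measured values. The expected value for compound 4 is 10000 nM with an estimated range from 4000 nM to 25000 nM around it.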

Compound 4, half-maximal inhibitory concentration: 6740 nM
Compound 4: middle estimate off by 1.5-fold (0.17 log units), on the high side, within the range that was stated.
By their numbers in this assay, from the lowest: compounds 4, 2, 3 and 1 (each within the scatter of the next, the first and the last beyond it).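

In this assay, within the data shown here, the change from methoxy to isopropoxy provides the first one-place comparison, and a 1.4-fold lower number from compound 2 to compound 4 (0.13 log units; within the scatter) stays within the scatter. At this position, on an oxygen on an aromatic ring whose other neighbours are aromatic nitrogen, isopropyl in place of methyl therefore leaves no difference that this read-out can resolve, even with 3 heavy atoms replacing 1. No measurement is available that bears on the reason for this result.

A single step cannot show whether a longer chain, a benzyl group or an amine-bearing chain on this oxygen would move the number beyond the scatter. From the compounds shown here alone, it is also open whether the same change behaves alike on the core of compound 3.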